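The source may report more compounds than this note shows. Statements on the series, on what has been measured and on what is new or still open speak of the compounds shown alone.

Measured compounds and their values:
- compound 1 `COc1cc2c(Oc3ccc(NC(=O)c4cn(-c5ccc(F)c(F)c5)nn4)cc3F)ccnc2cc1OCCCN1CCCCC1`: 210 nM
- compound 2 `COc1cc2c(Oc3ccc(NC(=O)c4cn(-c5ccccc5C)nn4)cc3F)ccnc2cc1OCCCN1CCN(C)CC1`: 1430 nM
- compound 3 `COc1cc2c(Oc3ccc(NC(=O)c4cn(-c5c(C)cccc5C)nn4)cc3F)ccnc2cc1OCCCN1CCN(C)CC1`: 2170 nM

In a functional assay on HT-29 cells (Homo sapiens) for cytotoxicity, read by MTT assay, with a stated time of 72 h (on this read-out higher numbers stand for weaker inhibition and lower numbers for stronger inhibition), compound 3 gives 2170 nM. Compound 2 gives 1430 nM, and the step of a 1.5-fold higher number from compound 2 to compound 3 (0.18 log units; within the scatter) is within the scatter, so compound 2 and compound 3 sit together at the weak end of the set. Compound 1, with 210 nM, stands well apart from both and is the strongest inhibitor of the three, its gaps to compound 2 and compound 3 lying beyond the scatter.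

Compound 4 `COc1cc2c(Oc3ccc(NC(=O)c4cn(-c5ccc(F)c(F)c5)nn4)cc3F)ccnc2cc1OCCCN1CCN(C)CC1` is obtained from compound 3 by the change (3,4-difluorophenyl in place of 2,6-dimethylphenyl on an aromatic nitrogen). For the measured compounds named here, no measured step covers this swap of the aryl group on its own: compound 1 carries the same 3,4-difluorophenyl as compound 4 but differs from compound 3 in a second place as well, so the numbers for compound 1 and compound 3 only bracket what the combined changes do. Going by the values given here, the only single step in hand, from compound 2 to compound 3, concerns a methyl and is small. Given that compound 1 with the 3,4-difluorophenyl gives 210 nM, compound 4 is expected to move toward stronger inhibition, with an estimated step of a 4.8-fold lower number from compound 3 to compound 4 (0.68 log units; beyond the scatter). Compound 4 is estimated at 450 nM, in the range 150 nM to 1500 nM.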

Compound 4, half-maximal inhibitory concentration: 430 nM
For compound 4 the middle estimate is 1.0-fold (0.02 log units) above the measured one; the measured number falls inside the stated range.
By their numbers in this assay, from the lowest: compound 1; then compound 4; then compounds 2 and 3 (each within the scatter of the next).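

For the compounds shown here, the aryl group on the aromatic nitrogen of the five-membered ring now shows a clear effect in this assay: 3,4-difluorophenyl in place of 2,6-dimethylphenyl gives a step (a 5.0-fold lower number from compound 3 to compound 4 (0.70 log units; beyond the scatter)), and in place of 2-methylphenyl it gives a step (a 3.3-fold lower number from compound 2 to compound 4 (0.52 log units; beyond the scatter)), while the only earlier step at this position, the added methyl (a 1.5-fold higher number from compound 2 to compound 3 (0.18 log units; within the scatter)), stayed within the scatter. Going by these compounds alone, compound 4 also gives the first reading of the far end of the molecule, where 4-methylpiperazin-1-yl in place of piperidin-1-yl on the saturated chain gives a smaller step that still lies beyond the scatter (a 2.0-fold higher number from compound 1 to compound 4 (0.31 log units; beyond the scatter)), so both places count in this assay. Nothing available explains why either change acts as it does.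

The compounds shown cannot separate the loss of the methyl groups from the arrival of the fluorines, a question that plain phenyl or 4-fluorophenyl on the same nitrogen would address. They also leave open how other amines at the end of the chain, such as morpholine, would compare with piperidin-1-yl and 4-methylpiperazin-1-yl.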